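Compound 3 to Compound 4: a Ring Swap on the Core

The source may hold more compounds than are shown below. What is called first, only, known or untested is meant among the compounds shown, and "the series" means these compounds.

The measured compounds are:
compound 1, `Cc1nc(-c2ccc(Cl)cc2)c(CC(=O)O)s1`, giving 41000 nM in an in vitro functional assay on HEK285-7 cells for antagonist activity at prostaglandin D2 receptor 2 (Homo sapiens), read by BRET and beta-arrestin recruitment; on this read-out higher numbers stand for weaker inhibition and lower numbers for stronger inhibition;
compound 2, `Nc1nc(-c2ccc(Cl)cc2)c(CC(=O)O)s1`, for which this assay reports only the limit > 100000 nM;
compound 3, `O=C(O)Cc1sc(C(c2ccc(F)cc2)c2ccc(F)cc2)nc1-c1cc(F)cc(F)c1`, giving 340 nM in this assay.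

Among the two numbers shown, compound 3 stands lowest, with compound 1 well apart, beyond the scatter. The unmeasured compound 4, `Cc1cc(-c2nc(C(c3ccc(F)cc3)c3ccc(F)cc3)sc2CC(=O)O)cnc1N`, differs from compound 3 in one place: 6-amino-5-methylpyridin-3-yl in place of 3,5-difluorophenyl on an aromatic carbon.

Among the measured compounds shown here, only one measured step is available, an at least 2.4-fold higher number from compound 1 to compound 2 (0.38 log units; beyond the scatter), and it rests on a value that sits at the limit of > 100000 nM in this assay, at which 1 of the 3 values shown sits, so its true size is not known beyond being at least modest. It bears on the present step only loosely: both bring an amino group onto an aromatic ring, but on different rings and with the rest of the molecule differing widely between compound 1 and compound 3. On this thin evidence a step toward a higher number, of modest size, is expected, with a wide band of uncertainty in this assay, estimated as a 2.9-fold higher number from compound 3 to compound 4 (0.47 log units; beyond the scatter). Compound 4 is therefore expected to give about 1000 nM in this assay, within roughly 200 nM to 6000 nM.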

Compound 4, half-maximal inhibitory concentration: > 100000 nM
Compound 4 ended at the assay's limit; the forecaster's own chance of this, stated with the estimate: 3%; at least 100-fold (2.00 log units) between middle value and limit.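

In this assay compound 4 gives > 100000 nM, which is a limit of the read-out and not a number. Among the compounds shown here, the change gives the first step at this aromatic carbon, next to the ring nitrogen, and it is large: an at least 290-fold higher number from compound 3 to compound 4 (2.46 log units; beyond the scatter). Both groups hold one six-membered aromatic ring and 8 heavy atoms, so this carbon clearly does not treat the two alike, and only a lower bound can be given for the size of the step: the limit of > 100000 nM in this assay, at which 2 of the 4 values shown sit.

The compounds shown leave open which part of 6-amino-5-methylpyridin-3-yl goes with the change, whether the amine, the methyl or the ring nitrogen, as all three enter together and no compound here separates them. They also leave open how simpler groups such as 6-aminopyridin-3-yl, 5-methylpyridin-3-yl or an unsubstituted phenyl would stand on this carbon, and so whether a single one of these features is enough to bring the read-out to the limit.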